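Losing a Chloro Group on the Benzyl Ring

This account rests on a few compounds, and the source may have more. Where it says the series, first, only, none or still open, it means among the compounds named here.

Compound 1, `O=S(=O)(NCCNCc1ccc(-c2ccccc2)cc1)c1cc(C(F)(F)F)cc(C(F)(F)F)c1`: 2800 nM
Compound 2, `O=S(=O)(NCCCNCc1cccc(Cl)c1)c1cc(C(F)(F)F)cc(C(F)(F)F)c1`: 5900 nM
Compound 3, `O=S(=O)(NCCNCc1cccc2ccccc12)c1cc(C(F)(F)F)cc(C(F)(F)F)c1`: 22000 nM

These three numbers come from a functional assay on ASPC1 cells (Homo sapiens) for inhibition, read by MTT assay, with a stated time of 72 h; a lower number here means a stronger inhibitor of growth, a higher number a weaker inhibitor of growth. Among them, compound 2 holds the second-highest number: compound 1 lies below it and compound 3 well above it, and both gaps are wider than the usual scatter of this assay. Compound 4, `O=S(=O)(NCCCNCc1ccccc1)c1cc(C(F)(F)F)cc(C(F)(F)F)c1`, has not yet been measured. It differs from compound 2 in a single spot: hydrogen in place of chloro on an aromatic carbon. For the measured compounds named here, no pair of measured compounds differs in only one place, so no measured step sets a scale for this change. The change is expected to weaken growth inhibition modestly in this assay, a step of a 1.5-fold higher number from compound 2 to compound 4 (0.18 log units; within the scatter). Compound 4 is therefore estimated at 9000 nM, with a range from 3500 nM to 23000 nM.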

Compound 4, concentration for 50% growth inhibition: 13000 nM
Beside the measured number, compound 4's estimate is 1.4-fold (0.16 log units) below it; low and high end bracket the measured number.
By their numbers in this assay, from the lowest: compound 1; then compound 2; then compounds 4 and 3 (each within the scatter of the next).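

In this assay, for the compounds shown here, swapping 3-chlorobenzyl for benzyl gives a 2.2-fold higher number from compound 2 to compound 4 (0.34 log units; beyond the scatter), the first measured step between compounds that differ in only one place. It shows that the chloro group on this aromatic carbon goes with stronger growth inhibition, by a margin greater than the usual scatter. Nothing measured here explains this difference.

From the compounds shown here alone, it remains open whether fluoro, methoxy or a carboxylic acid on the same carbon would match chloro. The compounds shown also cannot tell whether chloro would have the same effect elsewhere on the ring.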